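The source may report more compounds than this note shows. Statements on the series, on what has been measured and on what is new or still open speak of the compounds shown alone.

Measured so far:
- Compound 1 `O=C(N/N=C/c1ccc(F)cc1)Nc1cc2c(Nc3ccc(F)c(Cl)c3)ncnc2cc1O[C@H]1CCOC1`: 35100 nM
- Compound 2 `COc1ccc(/C=N/NC(=O)Nc2cc3c(Nc4ccc(F)c(Cl)c4)ncnc3cc2O[C@H]2CCOC2)c(OC)c1OC`: 25200 nM
- Compound 3 `COc1cc2ncnc(Nc3ccc(F)c(Cl)c3)c2cc1NC(=O)N/N=C/c1ccc(F)cc1`: 26600 nM

All three values come from a functional assay on A549 cells (Homo sapiens) for cytotoxicity, read by MTT assay, with a stated time of 72 h; a lower number here means a stronger inhibitor, a higher number a weaker inhibitor. Compound 3, at 26600 nM, lies within the scatter of both other compounds, so the three cannot be ranked.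

The next compound is compound 4 `COc1cc2ncnc(Nc3ccc(F)c(Cl)c3)c2cc1NC(=O)N/N=C/c1cc(OC)c(OC)c(OC)c1`, which is compound 3 with one change: 3,4,5-trimethoxyphenyl in place of 4-fluorophenyl on a carbon with a double bond to nitrogen. In words, 3,4,5-trimethoxyphenyl stands in place of 4-fluorophenyl on a carbon with a double bond to nitrogen.

For the measured compounds named here, two measured steps bear on this. The closest is a 1.4-fold lower number from compound 1 to compound 2 (0.14 log units; within the scatter), where 2,3,4-trimethoxyphenyl replaced 4-fluorophenyl at the same place. The other is a 1.3-fold lower number from compound 1 to compound 3 (0.12 log units; within the scatter), where methyl replaced oxolan-3-yl on an oxygen on an aromatic ring, and this shows the same kind of small difference. Neither step contains the 3,4,5-trimethoxyphenyl group itself, so this evidence is indirect.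

The expected result is no change beyond the scatter, with an estimated 1.2-fold lower number from compound 3 to compound 4 (0.08 log units; within the scatter). For compound 4 the estimated value is 22000 nM, with an expected range from 10000 nM to 45000 nM.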

Compound 4, half-maximal inhibitory concentration: 32100 nM
Estimate against measurement, compound 4: 1.5-fold (0.16 log units) below; the measured number falls inside the stated range.
By their numbers in this assay, from the lowest: compounds 2, 3, 4 and 1 (each within the scatter of the next).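

In this assay, the step of a 1.2-fold higher number from compound 3 to compound 4 (0.08 log units; within the scatter) shows that this place on the carbon with a double bond to nitrogen accepts 3,4,5-trimethoxyphenyl, with more heavy atoms and with hydrogen-bond acceptors where 4-fluorophenyl has none, without a change beyond the scatter. Read beside the step of a 1.4-fold lower number from compound 1 to compound 2 (0.14 log units; within the scatter), it shows that two different trimethoxyphenyl groups, each with a different group on the oxygen on the aromatic ring, both leave the number within the scatter of the matching 4-fluorophenyl compound. The data shown offer nothing that explains this lack of change.

From the compounds shown here alone, whether any group at this place can move the number beyond the scatter stays open, for instance a phenyl ring carrying an amine or a carboxylic acid, or a longer chain instead of a ring. Going by these compounds, how 3,4,5-trimethoxyphenyl behaves with oxolan-3-yl on the oxygen also stays open.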